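A Second Chloro Group on a Purine Core

The compounds below may be only part of what the source reports. "The series", "measured", "known", "first", "only" and "open" are said of these compounds alone.

Measured compounds:
Compound 1, `ClCc1ccccc1Cn1cnc2c(Cl)nc(Cl)nc21`: in a functional assay on LOX IMVI cells (Homo sapiens) for cytotoxicity, read by sulforhodamine B assay, with a stated time of 48 h (a higher number here means a weaker inhibitor of growth, a lower number a stronger inhibitor of growth), compound 1 gives 360 nM.
Compound 2, `ClCc1ccccc1Cn1cnc2c(Cl)ncnc21`: in this assay compound 2 gives 5240 nM.
Compound 3, `ClCc1cccc(Cn2cnc3c(Cl)ncnc32)c1`: in this assay compound 3 gives 5010 nM.

Compounds 2 and 3 carry the same atoms joined differently; the difference between the two cores is not broken down here. Their numbers in this assay lie within the scatter of each other, so nothing separates them.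

Compound 1 is compound 2 with one change, (chloro in place of hydrogen on an aromatic carbon). That change gave a 15-fold lower number from compound 2 to compound 1 (1.16 log units; beyond the scatter), a clear gain in growth inhibition.

Compound 4, `ClCc1cccc(Cn2cnc3c(Cl)nc(Cl)nc32)c1`, has not yet been measured. It stands to compound 3 as compound 1 stands to compound 2: the change is chloro in place of hydrogen on an aromatic carbon, and the surroundings of the new group are described in the same words in both cases, so this is the same change made on a closely related core.

Because the earlier step was a 15-fold lower number from compound 2 to compound 1 (1.16 log units; beyond the scatter), a step of similar size is expected here, giving a 14-fold lower number from compound 3 to compound 4 (1.16 log units; beyond the scatter). This rests on a single precedent, so a wider range is kept around the estimate.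

Compound 4 is therefore expected to give about 350 nM in this assay, most likely between 150 nM and 900 nM.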

Compound 4, concentration for total growth inhibition: 3380 nM
Compound 4: the middle estimate sits 9.7-fold (0.98 log units) below what was measured; measured number above the stated range.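

Placed on the core of compound 3, chloro in place of hydrogen on an aromatic carbon gives, in this assay, a 1.5-fold lower number from compound 3 to compound 4 (0.17 log units; within the scatter), so on this core the new group brings no gain that can be told apart from the ordinary spread of repeated measurements. The large step seen on the other core therefore did not carry over, and the two steps differ by more than their scatter allows: the same change on two cores in this assay, a 15-fold lower number (1.16 log units; beyond the scatter) from compound 2 to compound 1 and a 1.5-fold lower number (0.17 log units; within the scatter) from compound 3 to compound 4, 9.8-fold (0.99 log units) apart, beyond the scatter of two such steps

Together, the two pairs show that in this series the size of this step depends on the core that carries it, so one step on one core is a poor guide to the other, but with only two pairs they do not show which feature of the cores sets the gap or what the step would be on a further core.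

The compounds shown leave open whether another group on that same aromatic carbon, such as an amine or a methoxy group, would behave differently on the two cores. They also leave open whether such a group would follow the pattern of the chloro group, with a large step on one core and none that can be read on the other.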